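The compounds below may be only part of what the source reports. "The series", "measured", "known", "first", "only" and "open" are said of these compounds alone.

In a functional assay for agonist activity at growth hormone secretagogue receptor type 1 (Homo sapiens), read by FLIPR (on this read-out lower numbers stand for an effect already at smaller amounts and higher numbers for an effect only at larger amounts of compound), compound 1 `COc1cc2c(cc1N1C[C@@H](C)N[C@@H](C)C1)N(S(=O)(=O)c1ccc3ccccc3c1)CC2` gives 0.501 nM, the second highest of the three numbers. Compound 3 `COc1cc2c(cc1N1C[C@@H](C)N[C@@H](C)C1)N(S(=O)(=O)c1ccc(-c3ccccn3)cc1)CC2` gives 0.2 nM and compound 2 `COc1cc2c(cc1N1C[C@@H](C)N[C@@H](C)C1)N(S(=O)(=O)CCc1ccccc1Cl)CC2` gives 5.01 nM. Among the compounds with values here, the only single-point step measured is a 10-fold higher number from compound 1 to compound 2 (1.00 log units; beyond the scatter), where an aryl on the sulfonyl sulfur is replaced by an arylalkyl chain. Compound 4 `COc1cc2c(cc1N1C[C@@H](C)N[C@@H](C)C1)N(S(=O)(=O)c1ccc(-c3ccon3)s1)CC2` differs from compound 1 by 5-(1,2-oxazol-3-yl)thiophen-2-yl in place of naphthalen-2-yl on a sulfonyl sulfur. This keeps an aromatic group directly on the sulfonyl sulfur and, like compound 3 with its pyridinyl attached to the phenyl, adds a second ring bearing acceptors; the values of compound 1 and compound 3 show that such a biaryl-type group gives a lower number. Within the data shown here, no step bears directly on heteroaryl replacement, so in this assay compound 4 is expected to land close to compound 1, at most slightly lower, giving a 1.3-fold lower number from compound 1 to compound 4 (0.10 log units; within the scatter). The estimate for compound 4 is 0.4 nM, with a range of 0.13 nM to 1.3 nM.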

Compound 4, half-maximal effective concentration: 2.51 nM
Beside the measured number, compound 4's estimate is 6.3-fold (0.80 log units) below it; the whole stated range lies below it.
By their numbers in this assay, from the lowest: compound 3; then compound 1; then compounds 4 and 2 (each within the scatter of the next).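

In this assay, an aromatic group kept directly on the sulfonyl sulfur does not by itself hold the number low: 5-(1,2-oxazol-3-yl)thiophen-2-yl in place of naphthalen-2-yl gives a 5.0-fold higher number from compound 1 to compound 4 (0.70 log units; beyond the scatter) at this position. Against 2-(2-chlorophenyl)ethyl, the same group gives a 2.0-fold lower number from compound 2 to compound 4 (0.30 log units; within the scatter) and stays within the scatter, so these two groups are not separated here. Two linked rings are not enough either, since compound 3 gives 0.2 nM and compound 4 gives 2.51 nM in this read-out.

Open, from the compounds shown here alone, is which of the two five-membered aromatic rings carries the step, and whether a plain thiophen-2-yl on the sulfonyl sulfur would read like compound 1 or compound 4. No evidence at hand accounts for this step.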